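The source may report more compounds than this note shows. Statements on the series, on what has been measured and on what is new or still open speak of the compounds shown alone.

Measured so far in an assay on isolated protein for binding affinity to leukotriene B4 receptor 1 (Homo sapiens), tested at 1 uM; a lower number here means less inhibition, a higher number more inhibition at the concentration tested (going by the name of the read-out):
compound 1, `CCc1cc(C(C)=O)c(O)cc1OCCCCC(C)(C)C#N` — 30%
compound 2, `CCc1cc(C(C)=O)c(O)cc1OCCCCCCCC(C)(C)C#N` — 29%

Compound 1 and compound 2 lie within the scatter of each other; the step of a number 1 percentage points lower from compound 1 to compound 2 (within the scatter) is a lengthening of the nitrile-bearing chain and nothing more, so on the numbers shown compound 1 stands level with compound 2 rather than apart from it.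

Compound 3, `CCc1cc(C(C)=O)c(O)cc1OCCCC(C)(C)C(=O)O`, is the next step from compound 1: 1-carboxy-1-methylethyl in place of 2-cyano-2-methylpropyl on a saturated chain carbon, three bonds along the chain from an oxygen on an aromatic ring. Going by the values given here, no measured step exchanges the nitrile for a carboxylic acid; the single step in hand, which is within the scatter, speaks only for chain length and bears on this change indirectly at best. The direction of the step in this assay is therefore open, and the expectation is a small shift, most likely within the scatter, with wide uncertainty.

Estimated for compound 3: 35%, range 10% to 65%; this is an expected step of a number 5 percentage points higher from compound 1 to compound 3 (within the scatter).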

Compound 3, a percentage reported as inhibition, at one concentration (the size of the read-out at that concentration, not a potency): 43%
Beside the measured number, compound 3's estimate is 8 percentage points below it, and the stated range covers the measured number.
By their numbers in this assay, from the lowest: compounds 2 and 1 (each within the scatter of the next); then compound 3.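

In this assay, replacing 2-cyano-2-methylpropyl with 1-carboxy-1-methylethyl on a saturated chain carbon, three bonds along the chain from an oxygen on an aromatic ring, gives a number 13 percentage points higher from compound 1 to compound 3 (beyond the scatter). This shows that the read-out responds to a change at this position, whereas the chain lengthening among the nitriles gave only a number 1 percentage points lower from compound 1 to compound 2 (within the scatter). The entering group brings a hydrogen-bond donor that the leaving group lacks, but no measurement ties the step to that feature or explains it.

From the compounds shown here alone, it remains open whether the step belongs to the carboxylic acid itself or to its distance along the chain from the oxygen on the aromatic ring. Also open, going by these compounds, is whether a methyl ester or a primary amide at this position, or a carboxylic acid on a longer chain, would keep the higher inhibition.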